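The compounds below may be only part of what the source reports. "The series", "measured", "known", "first", "only" and "open" are said of these compounds alone.

For the measured compounds named here, in an ADME assay on NHDF cells (Homo sapiens) for cytotoxicity, read by MTT assay, with a stated time of 72 h (on this read-out higher numbers stand for weaker inhibition and lower numbers for stronger inhibition), compound 2 `COc1ccc(/C=C2\CCC/C(=C\c3ccc(Cl)cc3)C2=O)cc1OC` gives 11200 nM, the only plain number among the values shown. Compound 1 `COc1cccc(/C=C2\CCC/C(=C\c3cccc(Cl)c3Cl)C2=O)c1OC` reaches only a limit of the assay, > 50000 nM. Compound 3 `COc1cc(/C=C2\CCC/C(=C\c3ccc(OC)c(OC)c3)C2=O)ccc1O` has not been measured yet. It differs from compound 2 in one place: 4-hydroxy-3-methoxyphenyl in place of 4-chlorophenyl on a double-bonded chain carbon bound to a double-bonded ring carbon. Going by the values given here, no measured pair shows what such a change does here, so only an expectation can be offered: a small move toward weaker inhibition, probably within the usual scatter, is expected, a 1.4-fold higher number from compound 2 to compound 3 (0.15 log units; within the scatter). Compound 3 is therefore estimated at 16000 nM, within a range from 4000 nM to 50000 nM.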

Compound 3, half-maximal inhibitory concentration: 13700 nM
Compound 3: the middle estimate sits 1.2-fold (0.07 log units) above what was measured; low and high end bracket the measured number.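

For the compounds shown here, this is the first pair in this assay that differs in one place, and it gives a first reading of this change: a 1.2-fold higher number from compound 2 to compound 3 (0.09 log units; within the scatter). On a double-bonded chain carbon bound to a double-bonded ring carbon, 4-hydroxy-3-methoxyphenyl and 4-chlorophenyl cannot be told apart on this read-out, although only the entering group carries a hydrogen-bond donor and hydrogen-bond acceptors. No measurement shown bears on the cause of this result.

From the compounds shown here alone, whether other groups fit this place remains open. A phenyl ring carrying an amine or a carboxylic acid could give a different reading.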